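Adding a hydroxy to compound 3

The source may hold more compounds than are shown below. What is called first, only, known or untested is meant among the compounds shown, and "the series" means these compounds.

Compound 1 `COc1ccc(S(=O)(=O)Nc2cccc3cc(O)[nH]c23)cc1`: 0.22 ug/mL
Compound 2 `O=[N+]([O-])c1ccc(S(=O)(=O)Nc2cccc3cc(O)[nH]c23)cc1`: 62 ug/mL
Compound 3 `Nc1ccc(S(=O)(=O)Nc2cccc3cc[nH]c23)cc1`: 6.1 ug/mL

In a functional assay on MC-38 cells (Mus musculus) for antiproliferative activity, read by colorimetric assay and MTT assay (a lower number here means a stronger inhibitor, a higher number a weaker inhibitor), compound 3 gives 6.1 ug/mL, the middle of the three numbers. Compound 4 `Nc1ccc(S(=O)(=O)Nc2cccc3cc(O)[nH]c23)cc1` is still unmeasured. It is compound 3 with hydroxy in place of hydrogen on an aromatic carbon. Among the measured compounds shown here, no measured step tests this change directly. For the measured compounds named here, the one measured step, a 280-fold higher number from compound 1 to compound 2 (2.45 log units; beyond the scatter), is large, but it exchanges a different group between two compounds that both carry the hydroxy. Going by the values given here, it shows only that numbers for hydroxy-bearing compounds can spread widely. A moderate move toward a lower number is therefore expected, with real doubt about its size. The estimated move is a 4.1-fold lower number from compound 3 to compound 4 (0.61 log units; beyond the scatter). For compound 4 the estimated value is 1.5 ug/mL, with an expected range of 0.15 ug/mL to 15 ug/mL.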

Compound 4, half-maximal inhibitory concentration: 1.8 ug/mL
For compound 4 the middle estimate is 1.2-fold (0.08 log units) below the measured one; the measured number falls inside the stated range.
By their numbers in this assay, from the lowest: compound 1; then compound 4; then compound 3; then compound 2.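

In this assay, among the compounds shown here, hydroxy on an aromatic carbon next to the ring nitrogen gives a 3.4-fold lower number from compound 3 to compound 4 (0.53 log units; beyond the scatter), the first direct reading of this change. With that hydroxy present, amino in place of nitro gives a 34-fold lower number from compound 2 to compound 4 (1.54 log units; beyond the scatter), while amino in place of methoxy gives an 8.2-fold higher number from compound 1 to compound 4 (0.91 log units; beyond the scatter), so amino ranks in the middle of these three groups. No available evidence accounts for these shifts. Still open, from the compounds shown here alone, is whether a carboxylic acid or a methyl on that same carbon would lower the number, and whether hydroxy acts alike when methoxy or nitro replaces amino.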